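A Pyridazin-3-yl Replaces Thiophen-2-yl on Compound 3

The compounds below may be only part of what the source reports. "The series", "measured", "known", "first", "only" and "open" are said of these compounds alone.

Of the compounds shown here, three have been measured in an assay on Sf9 cells for inhibition of protein deacetylase HDAC6 (Homo sapiens), read by fluorescence; on this read-out lower numbers stand for stronger inhibition and higher numbers for weaker inhibition. Compound 1 `Cc1cc(-c2nnc(Sc3ccc(C(=O)NO)c(F)c3)n2C)nn1C` gives 2240 nM, compound 2 `NCc1ccc(C(=O)NO)cc1` gives 695 nM, and compound 3 `Cn1c(Sc2c(F)cc(C(=O)NO)cc2F)nnc1-c1cccs1` gives 9 nM. Among these, compound 3 stands lowest; the nearest number belongs to compound 2 and lies beyond the scatter, while the furthest belongs to compound 1 and lies still further off, so compound 3 is the most potent of the three on this read-out.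

The next compound, compound 4 `Cn1c(Sc2c(F)cc(C(=O)NO)cc2F)nnc1-c1cccnn1`, awaits measurement in this assay. It differs from compound 3 in a single place: pyridazin-3-yl in place of thiophen-2-yl on an aromatic carbon. Everything else in the shared core of compound 3 is retained.

Among the compounds with values here, no pair of measured compounds that differ in only one place is available, so no comparable step can be read from the numbers above. The change keeps the ring on the same carbon but exchanges a five-membered ring for a six-membered one with an added hydrogen-bond acceptor. For that reason the step from compound 3 to compound 4 is expected to be small, at most a mild weakening, a 1.7-fold higher number from compound 3 to compound 4 (0.22 log units; within the scatter). Compound 4 is therefore estimated at 15 nM, with a range from 4 nM to 60 nM.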

Compound 4, half-maximal inhibitory concentration: 13 nM
For compound 4 the middle estimate is 1.2-fold (0.06 log units) above the measured one; measured number inside the range.
By their numbers in this assay, from the lowest: compounds 3 and 4 (each within the scatter of the next); then compound 2; then compound 1.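

In this assay, within the data shown here, a 1.4-fold higher number from compound 3 to compound 4 (0.16 log units; within the scatter) is the first step that can be read at this place, the aromatic carbon between two ring nitrogen atoms, as none of the earlier compounds formed a pair that differed in one place. It shows that, on the shared core, pyridazin-3-yl and thiophen-2-yl cannot be told apart on this read-out, even though one is a six-membered aromatic ring with 2 hetero atoms and 2 hydrogen-bond acceptors and the other a five-membered aromatic ring with 1 hetero atom and 1 hydrogen-bond acceptor. No measurement at hand accounts for this result, so the pair records the outcome without explaining it.

Among these compounds, these two aromatic rings are the only groups that can be compared at this place, so it remains open whether a phenyl ring, an amine, a carboxylic acid or a longer chain on the same carbon would stay within the scatter of compound 3. As far as these compounds go, it is also open whether pyridazin-3-yl would match thiophen-2-yl in the same way if the fluorine atoms of the shared core gave way to hydrogen or chlorine.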